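Working notes: fluoro added to compound 2

A few compounds are considered here, and "the series" means these few. Any claim that something is new, unique, unknown or untested is made for them only; others in the source may bear on it.

Measured so far in a functional assay on A-375 cells (Homo sapiens) for antiproliferative activity, with a stated time of 72 h (a higher number here means a weaker inhibitor, a lower number a stronger inhibitor), for this series:
- compound 1 `C=C[C@@H]1C[C@@H](Cc2ccc(OC)c(O)c2)[C@H]2C(=O)C=CC(=C)[C@H]21` at 0.4 nM
- compound 2 `C=C1C=CC(=O)[C@@H]2[C@H](Cc3ccc(OCOC)cc3)CC[C@H]12` at 77.4 nM

Compound 2 holds the higher of the two numbers and is the weaker inhibitor of the pair, and the gap to compound 1 lies well beyond the scatter. The two differ in more than one place, so that gap cannot be assigned to any single change.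

Next in line is compound 3 `C=C1C=CC(=O)[C@@H]2[C@H](Cc3ccc(OCOC)c(F)c3)CC[C@H]12`, which differs from compound 2 by fluoro in place of hydrogen on an aromatic carbon and in no other way. This is fluoro in place of hydrogen on an aromatic carbon, ortho to a methoxymethoxy group. Among the measured compounds shown here, no measured step in this assay covers a change of this kind, so the expectation starts from compound 2 at 77.4 nM and from the modest size of the swap. A small step is expected, most likely none beyond the scatter, with no firm direction. The estimated move is a 1.2-fold lower number from compound 2 to compound 3 (0.08 log units; within the scatter) at this stage. Compound 3 is expected at 65 nM with an estimated range of 22 nM to 190 nM for now.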

Compound 3, half-maximal inhibitory concentration: 40 nM
Estimate against measurement, compound 3: 1.6-fold (0.21 log units) above, within the range that was stated.
By their numbers in this assay, from the lowest: compound 1; then compounds 3 and 2 (each within the scatter of the next).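

In this assay, the series now has its first step that changes a single place: fluoro in place of hydrogen on an aromatic carbon, ortho to a methoxymethoxy group, gives a 1.9-fold lower number from compound 2 to compound 3 (0.29 log units; within the scatter). This position therefore tolerates the added fluorine atom, at least with the rest of the structure held constant, and the step supports no ranking of the two compounds, since it stays within the scatter. Nothing available here bears on the reason for this result.

Going by these compounds, one substituent at one position cannot show whether this aromatic carbon is insensitive to substitution in general, so it remains open whether chloro, a nitrile, an amine or a carboxylic acid in the same place would also leave the number within the scatter. Also open, on these data alone, are the effect of fluoro on the other carbons of this ring and the effect of replacing the methoxymethoxy group while the fluoro stays in place.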